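The source may report more compounds than this note shows. Statements on the series, on what has been measured and on what is new or still open speak of the compounds shown alone.

In an ADME assay (liver) for metabolic stability, with Liver microsome (Rattus norvegicus) as the target, using microsomes (a higher number here means faster removal of the compound, a lower number slower removal), compound 2 `COc1ccc(-c2nn(-c3nc(C(=O)O)cs3)c3ccccc23)cc1` gives 618 mL/min/kg, well under compound 1 `O=C(O)c1csc(-n2cc(-c3ccccc3)c3ccccc32)n1` at 2400 mL/min/kg and close to compound 3 `O=C(O)c1csc(-n2nc(-c3ccc(C(F)(F)F)cc3)c3ccccc32)n1` at 809 mL/min/kg. Compound 4 `CC1CCN(c2nn(-c3nc(C(=O)O)cs3)c3ccccc23)CC1` carries 4-methylpiperidin-1-yl in place of 4-methoxyphenyl on an aromatic carbon. Within the data shown here, only one measured step touches this group: a 1.3-fold higher number from compound 2 to compound 3 (0.12 log units; within the scatter), with trifluoromethyl in place of methoxy. Among the measured compounds shown here, that step keeps the six-membered aromatic ring, which compound 4 gives up, so it is a weak guide, and no measured compound has a non-aromatic ring at this place. The expected step in this assay is therefore small and slightly upward, a 1.5-fold higher number from compound 2 to compound 4 (0.16 log units; within the scatter), with nothing beyond the scatter anticipated. For compound 4 the estimate is 900 mL/min/kg, with an expected range from 350 mL/min/kg to 2400 mL/min/kg.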

Compound 4, clearance: 260 mL/min/kg
The estimate for compound 4 lay 3.5-fold (0.54 log units) above the measured number, and the stated range ends above it.
By their numbers in this assay, from the lowest: compound 4; then compounds 2 and 3 (each within the scatter of the next); then compound 1.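

In this assay, among these compounds, this position accepts a non-aromatic ring joined through its nitrogen: 4-methylpiperidin-1-yl in place of 4-methoxyphenyl gives a 2.4-fold lower number from compound 2 to compound 4 (0.38 log units; beyond the scatter), whereas the only earlier step here kept the aromatic ring and stayed within the scatter. The change therefore matters more than swapping the group on that aromatic ring did. No measurement available here explains the drop. Still open, going by these compounds, is whether the ring nitrogen, the loss of aromaticity or the methyl drives it; a cyclohexyl, a morpholine or an unsubstituted piperidine could separate these.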